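This account rests on a few compounds, and the source may have more. Where it says the series, first, only, none or still open, it means among the compounds named here.

Measured in a functional assay on CCRF-CEM cells (Homo sapiens) for inhibition; on this read-out higher numbers stand for weaker inhibition and lower numbers for stronger inhibition:
- compound 1 `Cn1cc(C#N)c2ccc(Nc3ncc(-c4ccccc4)o3)cc21`: 8000 nM
- compound 2 `Cn1cc(C#N)c2ccc(Nc3ncc(-c4cccc(NC(=O)c5ccccc5)c4)o3)cc21`: 3500 nM
- compound 3 `Cn1cc(C#N)c2ccc(Nc3ncc(-c4ccc(CNC(=O)C(C)(C)C)cc4)o3)cc21`: 4900 nM

Compound 1 stands level with compound 3 within the scatter and apart from compound 2. Unmeasured is compound 4 `Cn1cc(C#N)c2ccc(Nc3ncc(-c4ccccc4CNC(=O)OCCC#N)o3)cc21`, with the change ((((2-cyanoethoxy)carbonyl)amino)methyl in place of hydrogen on an aromatic carbon), which is (((2-cyanoethoxy)carbonyl)amino)methyl in place of hydrogen on an aromatic carbon, ortho to a large group. For the measured compounds named here, two measured steps bear on it: a 2.3-fold lower number from compound 1 to compound 2 (0.36 log units; beyond the scatter), and a 1.6-fold lower number from compound 1 to compound 3 (0.21 log units; within the scatter). Both run to lower numbers and both are small, so only a small step in this assay is expected, in the same direction and probably not beyond the scatter. The expected change is a 1.8-fold lower number from compound 1 to compound 4 (0.25 log units; within the scatter). The estimate for compound 4 is 4500 nM, with an expected range of 2000 nM to 10000 nM.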

Compound 4, half-maximal inhibitory concentration: > 10000 nM
Compound 4 gave a limit, no number; the forecaster's own chance of this, stated with the estimate: 10%; at least 2.2-fold (0.34 log units) between middle value and limit.
By their numbers in this assay, from the lowest: compounds 2, 3 and 1 (each within the scatter of the next, the first and the last beyond it). At a limit, above all of these: compound 4.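

Compound 4 reads only as a limit in this assay, not as a number: the limit of > 10000 nM in this assay, at which 1 of the 4 values shown sits. The step is an at least 1.2-fold higher number from compound 1 to compound 4 (0.09 log units; that floor lies within the scatter), so this change does not carry on the lower numbers seen with the two earlier substituents, though its floor does not separate compound 4 from compound 1. Compound 4 is also the only one shown with its substituent ortho to a large group.

The compounds shown do not separate the effect of this place from that of the (((2-cyanoethoxy)carbonyl)amino)methyl group itself. Going by these compounds, whether a smaller aminomethyl group or a carboxylic acid at this place would give a measurable number remains open.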